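The Same Methoxy Step Taken on a Second Core

The compounds below may be only part of what the source reports. "The series", "measured", "known", "first", "only" and "open" are said of these compounds alone.

Measured so far in an assay on HEK293 cells for agonist activity at probable G-protein coupled receptor 34 (Mus musculus), with a stated time of 1 h; a higher number here means a larger maximal response, a lower number a smaller maximal response:
compound 1, `CCCCCCCC/C=C\CCCCCCCC(=O)OC[C@H](C)OP(=O)(O)OC[C@H](N)C(=O)O`, 11.2%
compound 2, `CCCCCCCC/C=C\CCCCCCCC(=O)OC[C@H](COC)OP(=O)(O)OC[C@H](N)C(=O)O`, 7.5%
compound 3, `C[C@H](COC(=O)CCc1ccccc1OCc1cccc(Oc2ccccc2)c1)OP(=O)(O)OC[C@H](N)C(=O)O`, 12.4%

Compound 1 and compound 2 share one core and differ by a single change, (methoxy in place of hydrogen on a saturated chain carbon, two bonds along the chain from an oxygen on an unsaturated carbon). This change gave a number 3.7 percentage points lower from compound 1 to compound 2 (within the scatter). Compound 3 carries a different core; how its core differs from that of compound 1 is not broken down here. Its maximal response stands alongside those of compound 1 and compound 2, and all three numbers lie within the scatter of one another, so no order among them can be read.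

Compound 4, `COC[C@H](COC(=O)CCc1ccccc1OCc1cccc(Oc2ccccc2)c1)OP(=O)(O)OC[C@H](N)C(=O)O`, has not yet been measured. Among the measured compounds shown here, it differs from compound 3 by methoxy in place of hydrogen on a saturated chain carbon, two bonds along the chain from an oxygen on an unsaturated carbon, which is the same change, at the same place, as the one from compound 1 to compound 2. On the second core this change is expected to give a number 3.4 percentage points lower from compound 3 to compound 4 (within the scatter), resting on the step of a number 3.7 percentage points lower from compound 1 to compound 2 (within the scatter) seen on the first core. Compound 4 is therefore estimated to reach 9%, with a likely range from 3% to 16%.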

Compound 4, largest response reached (Emax), in percent of the reference or control that the assay uses: 13.5%
Estimate against measurement, compound 4: 4.5 percentage points below; the measured number falls inside the stated range.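

On the second core, methoxy in place of hydrogen gave a number 1.1 percentage points higher from compound 3 to compound 4 (within the scatter) in this assay. Set beside the step on the first core, this step cannot be told apart from it: the same change on two cores in this assay, a number 3.7 percentage points lower (within the scatter) from compound 1 to compound 2 and a number 1.1 percentage points higher (within the scatter) from compound 3 to compound 4, 4.8 percentage points apart, within the scatter of two such steps

Among the compounds shown here, the change can therefore be said to have carried from one core to the other without any measurable difference between the two steps, but this does not show that the change moves the maximal response on either core, nor that it would keep a fixed size or direction on others, since both steps lie within the scatter and only two cores are at hand.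

The compounds shown hold only methoxy at this place, which leaves open whether a hydroxyl, an amine or a longer alkoxy chain there would give a step beyond the scatter. They also leave open how the same change would behave on a third core, or in any read-out other than this assay.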